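A few compounds are considered here, and "the series" means these few. Any claim that something is new, unique, unknown or untested is made for them only; others in the source may bear on it.

In a functional assay on NCI-H460 cells (Homo sapiens) for antiproliferative activity, read by MTT assay, with a stated time of 48 h (a lower number here means a stronger inhibitor, a higher number a weaker inhibitor), compound 1 `COc1ccc(-c2nc3cccc(-c4cc(OC)c(OC)c(OC)c4)c3o2)cc1F` gives 2800 nM, compound 2 `COc1cc(-c2cccc3nc(-c4ccc(F)cc4)oc23)cc(OC)c1OC` gives 8700 nM and compound 3 `COc1cc(-c2cccc3nc(-c4cccc(O)c4)oc23)cc(OC)c1OC` gives 1900 nM. Compound 3 therefore cannot be separated from compound 1, but its number sits clearly under that of compound 2. Compound 4 `COc1cc(-c2cccc3nc(-c4cccc(N)c4)oc23)cc(OC)c1OC` carries one change: amino in place of hydroxy on an aromatic carbon. Among the compounds with values here, no measured step makes this exact swap. The closest evidence comes from replacing the whole aromatic group, which gave a 3.1-fold higher number from compound 1 to compound 2 (0.49 log units; beyond the scatter), a 1.5-fold lower number from compound 1 to compound 3 (0.17 log units; within the scatter) and a 4.6-fold lower number from compound 2 to compound 3 (0.66 log units; beyond the scatter), all modest or smaller. A change of a single atom is expected to do no more, and its direction cannot be told from these data. The expected step is a 1.1-fold lower number from compound 3 to compound 4 (0.02 log units; within the scatter), probably nothing beyond the scatter. For compound 4 the estimated value is 1800 nM, within an expected range of 650 nM to 5000 nM.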

Compound 4, half-maximal inhibitory concentration: 2600 nM
The estimate for compound 4 lay 1.4-fold (0.16 log units) below the measured number, within the range that was stated.
By their numbers in this assay, from the lowest: compounds 3, 4 and 1 (each within the scatter of the next); then compound 2.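

In this assay, the single-atom swap on this ring leaves the number essentially unchanged (a 1.4-fold higher number from compound 3 to compound 4 (0.14 log units; within the scatter)), so hydroxy and amino cannot be told apart at this place. Compound 4 also cannot be separated from the larger-substituted compound 1 (a 1.1-fold lower number from compound 1 to compound 4 (0.03 log units; within the scatter)), while the step from the 4-fluorophenyl compound (a 3.3-fold lower number from compound 2 to compound 4 (0.52 log units; beyond the scatter)) shows that amino, like hydroxy, gives a lower number than compound 2. Nothing measured here explains these results.

As far as these compounds go, whether a carboxylic acid or a methylamino group at this place would hold the same level remains open.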